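Trading a thiocarbamate for a bare amine on the shared core

A few compounds are considered here, and "the series" means these few. Any claim that something is new, unique, unknown or untested is made for them only; others in the source may bear on it.

Of the compounds shown here, two have been measured so far. Compound 1 `CC(=O)OC1C[C@@H]2CCCC[C@@H]2[C@H]1/C=C/c1ccc(-c2cccc(F)c2)cn1` carries an acetate ester on the saturated ring, and in an assay on cell membranes for displacement of a labelled ligand from proteinase-activated receptor 1 (Homo sapiens), read by scintillation counting, with a stated time of 60 min (on this read-out higher numbers stand for weaker inhibition and lower numbers for stronger inhibition), compound 1 gives 67 nM. Compound 2 `CN(C)C(=S)OC1C[C@@H]2CCCC[C@@H]2[C@H]1/C=C/c1ccc(-c2cccc(F)c2)cn1` keeps the same oxygen but bears a dimethylthiocarbamate on it, and in this assay compound 2 gives 120 nM. For the measured compounds named here, compound 2 thus holds the highest number of the two, but the only step recorded, a 1.8-fold higher number from compound 1 to compound 2 (0.25 log units; within the scatter), is within the scatter, so the two compounds cannot be told apart on these numbers.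

Compound 3 `NC1C[C@@H]2CCCC[C@@H]2[C@H]1/C=C/c1ccc(-c2cccc(F)c2)cn1` is a different kind of change: one nitrogen atom in place of a group of 6 heavy atoms (3 carbon, 1 nitrogen, 1 oxygen, 1 sulfur; no ring), on a saturated ring carbon. The oxygen itself disappears along with everything attached to it, and an amino group takes its place on the saturated ring carbon. Going by the values given here, the one measured step only shows that swapping the group hanging on that oxygen barely moved the number; nothing measured here tells what removing the oxygen and its whole substituent does. The expectation is therefore loosely anchored and the range is wide. Compound 3 is estimated at 150 nM in this assay, spanning 30 nM to 800 nM, which as a step means a 1.3-fold higher number from compound 2 to compound 3 (0.10 log units; within the scatter) is expected.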

Compound 3, half-maximal inhibitory concentration: 230 nM
Compound 3: middle estimate off by 1.5-fold (0.19 log units), on the low side; measured number inside the range.
By their numbers in this assay, from the lowest: compounds 1, 2 and 3 (each within the scatter of the next, the first and the last beyond it).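

Compound 3 shows that this saturated ring carbon does not need an oxygen-linked group for a nanomolar number in this assay, something the earlier pair could not show, since both of its members keep that oxygen. For the compounds shown here, removing the whole dimethylthiocarbamate along with its oxygen and placing an amino group there gives a 1.9-fold higher number from compound 2 to compound 3 (0.28 log units; within the scatter), so compound 2 and compound 3 cannot be told apart, while the comparison of amino with acetoxy gives a 3.4-fold higher number from compound 1 to compound 3 (0.54 log units; beyond the scatter) and is the first readable difference at this position, though a modest one. Nothing measured on these compounds accounts for that difference.

With only an ester, a thiocarbamate and an amino group at this position, these numbers cannot separate the effect of the atom attached to the ring from the effect of what that atom carries. From the compounds shown here alone, an acetamide, which would place the acetyl group of compound 1 on the nitrogen of compound 3, or a plain hydroxyl group could fall anywhere relative to these three, so how each would read out remains open.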